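This account rests on a few compounds, and the source may have more. Where it says the series, first, only, none or still open, it means among the compounds named here.

Working notes on the series. Within the data shown here, compound 1 `Cc1cccc(-c2ccc(CCC(=O)N3CCCC3)cc2)c1` is the only member with a number in an assay on HEK293 cells for inhibition of N-acylethanolamine-hydrolyzing acid amidase (Rattus norvegicus), read by LC-MS, with a stated time of 30 min; on this read-out lower numbers stand for stronger inhibition and higher numbers for weaker inhibition: compound 1 gives 16500 nM. Compound 2 `COc1cccc(CCCCCCC(=O)N2CCCC2)c1` returns no number in this assay but a limit; for compound 2 the result is > 100000 nM, which is the limit of > 100000 nM in this assay, at which 1 of the 2 values shown sits. Among the measured compounds shown here, with one number and one limit, compound 1 stands as the sole measured point against which anything can be judged, and no step between measured compounds can be drawn from what has been measured.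

Compound 3 `O=C(CCc1ccc(C2CCCCC2)cc1)N1CCCC1` has not yet been measured in this assay. It differs from compound 1 in one place: cyclohexyl in place of 3-methylphenyl on an aromatic carbon. Nothing measured in the series speaks to this exchange of cyclohexyl for 3-methylphenyl, so the direction of the step rests on expectation alone. The expected step is a 1.1-fold lower number from compound 1 to compound 3 (0.04 log units; within the scatter), which is to say none beyond the usual scatter. For compound 3 the estimate in this assay is 15000 nM, within an expected range of 4000 nM to 60000 nM.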

Compound 3, half-maximal inhibitory concentration: 500 nM
For compound 3 the middle estimate is 30-fold (1.48 log units) above the measured one, and the stated range ends above it.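

In this assay, this place, on an aromatic carbon of a six-membered aromatic ring of carbon only and para to a group of 9 heavy atoms, proves sensitive to the ring it carries: cyclohexyl in place of 3-methylphenyl gives a 33-fold lower number from compound 1 to compound 3 (1.52 log units; beyond the scatter), the first step the series can show. The exchange replaces an aromatic ring with a non-aromatic one and drops from 7 heavy atoms to 6, while neither group has hydrogen-bond donors, hydrogen-bond acceptors or a net charge, so a step of this size arises with those counts unchanged. Nothing measured in the series gives a cause for this step.

Going by these compounds, it remains open whether the step follows the saturated ring or the loss of the methyl group: a plain phenyl at this place would separate the two, and a cyclopentyl or a tert-butyl would show how much of the cyclohexyl ring the number depends on. On these data alone, it is also open whether a hydroxyl or an amine on the cyclohexyl ring would keep the number at this level.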